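This account rests on a few compounds, and the source may have more. Where it says the series, first, only, none or still open, it means among the compounds named here.

Going by the values given here, compound 1 `O=C(CSc1nc(Nc2ccccc2)c2ccccc2n1)Nc1cccc(F)c1` gives 12700 nM in a functional assay on MGC-803 cells (Homo sapiens) for inhibition, read by MTT assay, with a stated time of 72 h (a higher number here means a weaker inhibitor, a lower number a stronger inhibitor), and compound 2 `O=C(CSc1nc(Nc2ccccc2)c2ccccc2n1)Nc1cccc(Cl)c1` gives 14300 nM; the one measured step, a 1.1-fold higher number from compound 1 to compound 2 (0.05 log units; within the scatter), is small. Compound 3 `C=CC(=O)Nc1cccc(NC(=O)CSc2nc(Nc3cccc(C)c3)c3ccccc3n2)c1` gives 20900 nM, the highest of the three numbers, though its gaps to compound 2 and compound 1 both lie within the scatter. Compound 4 `C=CC(=O)Nc1cccc(NC(=O)CSc2nc(Nc3ccc(Cl)cc3Cl)c3ccccc3n2)c1` differs from compound 3 by 2,4-dichlorophenyl in place of 3-methylphenyl on a nitrogen on an aromatic ring. Among the compounds with values here, no measured step touches this position; the only step, between the two halogens of compound 1 and compound 2, lay within the scatter and concerns another ring. The analyst therefore expects no step beyond the scatter, a 1.2-fold lower number from compound 3 to compound 4 (0.06 log units; within the scatter), and estimates compound 4 at 18000 nM, within a range from 7000 nM to 45000 nM.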

Compound 4, half-maximal inhibitory concentration: 12100 nM
For compound 4 the middle estimate is 1.5-fold (0.17 log units) above the measured one, within the range that was stated.
By their numbers in this assay, from the lowest: compounds 4, 1, 2 and 3 (each within the scatter of the next).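

In this assay, going by these compounds alone, the only measured step on this nitrogen, 2,4-dichlorophenyl in place of 3-methylphenyl, is a 1.7-fold lower number from compound 3 to compound 4 (0.24 log units; within the scatter) and stays small. For this pair, the position takes the two chlorines in place of the methyl without a step beyond the scatter. No evidence at hand accounts for the result. Still open, as far as these compounds go, is whether an amine or a carboxylic acid on this aromatic ring, or a longer chain in place of the ring, would give a step beyond the scatter. A single pair also cannot show how each chlorine contributes on its own.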